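Bromo in place of methyl on the kallikrein-7 inhibitor core

This account rests on a few compounds, and the source may have more. Where it says the series, first, only, none or still open, it means among the compounds named here.

Measured so far:
compound 1 `CC1=NC(c2cn(S(=O)(=O)c3ccc(Cl)cc3)c3ccccc23)CN1` gives 5700 nM in an assay on isolated protein for inhibition of kallikrein-7 (Homo sapiens), read by fluorescence, with stated times of 10 min and 30 min; on this read-out lower numbers stand for stronger inhibition and higher numbers for weaker inhibition
compound 2 `CC1=NC(c2cn(S(=O)(=O)c3ccc(Cl)cc3)c3ccc(C)cc23)CN1` gives 1900 nM in this assay

Among the compounds with values here, compound 2 stands at the lower of the two numbers in this assay; its only neighbour is compound 1, and the change of methyl in place of hydrogen on an aromatic carbon gave a 3.0-fold lower number from compound 1 to compound 2 (0.48 log units; beyond the scatter). Compound 3 `CC1=NC(c2cn(S(=O)(=O)c3ccc(Cl)cc3)c3ccc(Br)cc23)CN1` has not yet been measured in this assay. It differs from compound 2 in one place: bromo in place of methyl on an aromatic carbon. Within the data shown here, no measured step swaps one substituent for another at this carbon; the only step at hand, from compound 1 to compound 2, shows that a small group at this site can move the number by a modest amount. A bromo group of one heavy atom in place of a methyl of one heavy atom is expected to shift the number by about a 1.3-fold lower number from compound 2 to compound 3 (0.10 log units; within the scatter), which may fall within the scatter. Compound 3 is therefore estimated at 1500 nM, in a range from 500 nM to 4500 nM.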

Compound 3, half-maximal inhibitory concentration: 4700 nM
Estimate against measurement, compound 3: 3.1-fold (0.50 log units) below; the measured number lies above the stated range.
By their numbers in this assay, from the lowest: compound 2; then compounds 3 and 1 (each within the scatter of the next).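

In this assay, bromo in place of methyl on this aromatic carbon gave a 2.5-fold higher number from compound 2 to compound 3 (0.39 log units; beyond the scatter) here, so the position tells apart two groups of one heavy atom each, neither carrying a hydrogen-bond donor, a hydrogen-bond acceptor or a net charge. Bromo in place of hydrogen at the same carbon gave a 1.2-fold lower number from compound 1 to compound 3 (0.08 log units; within the scatter) and so did not reproduce the step seen with methyl, which shows that the lower number of compound 2 does not extend to every small group placed here. Nothing measured on hand accounts for the difference between methyl and bromo at this carbon.

Going by these compounds, it remains open where an ethyl chain, a methoxy group, an amine or a carboxylic acid at this carbon would fall. Also open, on these data alone, is whether methyl and bromo would differ in the same way on other versions of the shared core.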